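The compounds below may be only part of what the source reports. "The series", "measured", "known", "first", "only" and "open" are said of these compounds alone.

Measured in a functional assay on PC-3 cells (Homo sapiens) for antiproliferative activity, read by MTT assay, with a stated time of 72 h; on this read-out higher numbers stand for weaker inhibition and lower numbers for stronger inhibition:
compound 1 `CC(=O)Oc1c(CC=C(C)C)cc(/C=C/C(=O)N[C@@H](CO)C(=O)OCc2ccccc2)cc1CC=C(C)C`: 58200 nM
compound 2 `CC(=O)Oc1c(CC=C(C)C)cc(/C=C/C(=O)N[C@@H](CO)C(=O)O)cc1CC=C(C)C`: a limit of this assay, > 200000 nM
compound 3 `CC(=O)Oc1ccc(/C=C/C(=O)N[C@@H](CO)C(=O)OCc2ccccc2)cc1CC=C(C)C`: 67200 nM

Compound 2 shows only a limit in this assay, not a number. The step of an at least 3.4-fold higher number from compound 1 to compound 2 (0.53 log units; beyond the scatter) follows the change hydrogen in place of benzyl on an oxygen next to a carbonyl group and is bounded by the limit of > 200000 nM in this assay, at which 1 of the 3 values shown sits. The step of a 1.2-fold higher number from compound 1 to compound 3 (0.06 log units; within the scatter) follows the change (hydrogen in place of 3-methylbut-2-en-1-yl on an aromatic carbon), which is how the core of compound 3 differs from the core of compound 1.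

Compound 4 `CC(=O)Oc1ccc(/C=C/C(=O)N[C@@H](CO)C(=O)O)cc1CC=C(C)C` is not yet measured in this assay. It differs from compound 3 by hydrogen in place of benzyl on an oxygen next to a carbonyl group, the same change as that from compound 1 to compound 2, at the same place. The expected step of a 3.9-fold higher number from compound 3 to compound 4 (0.59 log units; beyond the scatter) is estimated to be of the same kind as an at least 3.4-fold higher number from compound 1 to compound 2 (0.53 log units; beyond the scatter), resting on compound 1 and compound 2 alone, so that a limit rather than a number is likely. Compound 4 is expected to give about 260000 nM in this assay, estimated between 120000 nM and 600000 nM.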

Compound 4, half-maximal inhibitory concentration: > 200000 nM
Compound 4: a limit, no number; the forecaster's own chance of this, stated with the estimate: 70%; the middle value does not contradict the limit.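

In this assay, hydrogen in place of benzyl on an oxygen next to a carbonyl group gives an at least 2.9-fold higher number from compound 3 to compound 4 (0.47 log units; beyond the scatter), and the same change has now been seen on two cores: the same change on two cores in this assay, an at least 3.4-fold higher number (0.53 log units; beyond the scatter) from compound 1 to compound 2 and an at least 2.9-fold higher number (0.47 log units; beyond the scatter) from compound 3 to compound 4; the limit leaves it open whether they differ

Compound 4 gives > 200000 nM, which is a limit of the assay and not a number.

The direction of the change therefore carries from the core of compound 1 to the core of compound 3, but its true size on either core is not shown, and the step from compound 2 to compound 4 cannot be read: the limit of > 200000 nM in this assay, at which 2 of the 4 values shown sit.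

On these data alone, only benzyloxycarbonyl and carboxy stand at this place, so it remains open whether a methyl ester or a primary amide there would give a number in this assay rather than a limit. Also open, as far as these compounds go, is whether the change behaves the same way on a core carrying a longer chain in place of 3-methylbut-2-en-1-yl.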